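A few compounds are considered here, and "the series" means these few. Any claim that something is new, unique, unknown or untested is made for them only; others in the source may bear on it.

Measured so far in a functional assay on PC-3 cells (Homo sapiens) for inhibition, read by sulforhodamine B assay, with a stated time of 48 h; a lower number here means a stronger inhibitor of growth, a higher number a weaker inhibitor of growth:

Compound 1 `Nc1cc(N)c2nc(-c3ccccc3)c(NCc3ccc(Cl)c(Cl)c3)nc2c1`: 1740 nM
Compound 2 `Nc1cc(N)c2nc(-c3ccccc3)c(Oc3ccc(F)cc3)nc2c1`: 8320 nM

Of these two, compound 1 stands with the lower number, and compound 2 stands apart from it by a gap that lies beyond the usual scatter of repeated measurements. The two compounds differ in more than one place, so nothing is drawn from their comparison beyond what the two values themselves show.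

Compound 3 `COc1ccc(CNc2nc3cc(N)cc(N)c3nc2-c2ccccc2)cc1` has not yet been measured in this assay. Against compound 1 it differs in one place: 4-methoxyphenyl in place of 3,4-dichlorophenyl on a saturated chain carbon bound to a nitrogen on an aromatic ring. For the measured compounds named here, no step between two measured compounds covers this kind of change, so the expectation rests only on the values of compound 1 and compound 2 and on the change itself.

The step expected from the change is a 2.3-fold higher number from compound 1 to compound 3 (0.36 log units; beyond the scatter), a shift toward a weaker inhibitor of growth that is expected to fall beyond the scatter but not far. Compound 3 is therefore expected to give about 4000 nM in this assay, with a likely range from 1500 nM to 12000 nM.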

Compound 3, concentration for 50% growth inhibition: 10200 nM
Estimate against measurement, compound 3: 2.6-fold (0.41 log units) below; measured number inside the range.
By their numbers in this assay, from the lowest: compound 1; then compounds 2 and 3 (each within the scatter of the next).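

In this assay, for the compounds shown here, 4-methoxybenzyl in place of 3,4-dichlorobenzyl gives a 5.9-fold higher number from compound 1 to compound 3 (0.77 log units; beyond the scatter), the first step that can be read at this position. Compound 1 and compound 2 differ in more than one place and could show no such thing, whereas this pair shows that, with the shared core held fixed, changing only what the phenyl ring on this chain carries moves the number beyond the scatter, toward a weaker inhibitor of growth. No measurement is at hand that would account for the size or the direction of this step.

Because the change removes both chlorine atoms and brings in a methoxy group in a single exchange, the two parts of it cannot be told apart, and an unsubstituted phenyl, a 4-chlorophenyl or a 3-chlorophenyl on the same chain would be needed to separate them. Going by these compounds, it also remains open how the number would respond to a different kind of group at this place, such as a pyridine ring in place of the phenyl ring or a longer chain in place of the benzyl carbon.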